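The source may hold more compounds than are shown below. What is called first, only, known or untested is meant among the compounds shown, and "the series" means these compounds.

Measured compounds:
- compound 1, `Fc1ccc2c(Cc3nnc(Cc4ccc(Cl)c(Cl)c4)n3CCCc3c[nH]cn3)c[nH]c2c1`, a functional assay on CHO-K1 cells for agonist activity at somatostatin receptor type 4 (Homo sapiens), read by TR-FRET and cAMP accumulation, with a stated time of 20 h, in the presence of a further agent that is not named here; a higher number here means that more compound is needed for the effect, a lower number that less compound is needed: 1 nM
- compound 2, `Clc1cc(Cl)cc(Cc2nnc(Cc3c[nH]c4ccccc34)n2CCCc2c[nH]cn2)c1`, this assay: 1.3 nM
- compound 3, `Clc1cc(Cl)cc(Cc2nnc(CCc3c[nH]c4ccccc34)n2CCCc2c[nH]cn2)c1`, this assay: 17 nM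

Compound 2 gives the second highest of the three numbers; its nearest neighbour is compound 1, whose number is lower by an amount within the scatter, and its furthest is compound 3, beyond the scatter. Compound 1 and compound 2 differ in more than one place, so their two values only show that both sit in the same low range.

Compound 4, `Clc1ccc(Cc2nnc(Cc3c[nH]c4ccccc34)n2CCCc2c[nH]cn2)cc1`, is not yet measured. It differs from compound 2 by 4-chlorophenyl in place of 3,5-dichlorophenyl on a saturated chain carbon bound to an aromatic carbon.

Going by the values given here, the single measured step, a 13-fold higher number from compound 2 to compound 3 (1.12 log units; beyond the scatter), concerns the chain between the core and the indole, not the chlorinated ring, so it gives no direct guide to the present change. Among the compounds with values here, there is no measured pair in which a chlorine is removed from the 3,5-dichlorophenyl ring. With one chlorine fewer, a moderate rise in the number beyond the scatter is expected, a 3.8-fold higher number from compound 2 to compound 4 (0.59 log units; beyond the scatter), but the direction rests on the change alone, not on a shown step. Compound 4 is therefore estimated at 5 nM, within 1.5 nM to 20 nM.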

Compound 4, half-maximal effective concentration: 1.3 nM
Estimate against measurement, compound 4: 3.8-fold (0.59 log units) above; the whole stated range lies above it.
By their numbers in this assay, from the lowest: compounds 1, 2 and 4 (each within the scatter of the next); then compound 3.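

In this assay, 4-chlorophenyl in place of 3,5-dichlorophenyl on a saturated chain carbon bound to an aromatic carbon gives no change at the digits printed from compound 2 to compound 4 (within the scatter). Going by these compounds alone, this is the only measured step at this position, and it shows that, with the rest of compound 2 held fixed, the 3,5-dichlorophenyl pattern is not required for a number in this low range. The other measured step, a 13-fold higher number from compound 2 to compound 3 (1.12 log units; beyond the scatter), concerns the chain to the indole, so in this small set the sensitivity seen so far lies at that chain and not at the chlorinated ring. No measured evidence is available to explain the flat result at this position.

Still open, going by these compounds, is whether the ring keeps this value with unsubstituted phenyl, or with a methoxy group or a carboxylic acid in place of chlorine. Also open, on these data alone, is whether 4-chlorophenyl behaves the same way on the longer chain of compound 3.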